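The compounds below may be only part of what the source reports. "The series", "measured", "known", "first", "only" and "open" are said of these compounds alone.

Four short fluorinated alcohols make up this set. Compound 1 `CC(O)CCC(F)F` carries a methyl group on the carbon that bears the oxygen; compound 2 `OCCCC(F)F` lacks it. Compound 3 `CCC(F)CCO` bears a single fluorine atom on its chain, and compound 4 `CC(F)CCO` is its shorter counterpart. How the core of compound 3 differs from the core of compound 1 is not broken down here.

In a physicochemical assay for lipophilicity, read by NMR (on this read-out lower numbers stand for lower lipophilicity and higher numbers for higher lipophilicity), compound 1 gives 0.64. In this assay compound 2 gives 0.29, so that a number 0.35 log units lower from compound 1 to compound 2 (beyond the scatter). The change behind that step is hydrogen in place of methyl on a saturated chain carbon bound to an oxygen on a saturated carbon and a saturated chain carbon. In this assay compound 3 gives 0.75; its value and that of compound 1 lie within the scatter of each other, while compound 2 sits well apart from both.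

Compound 4 has not yet been measured in this assay. The change that leads to it is hydrogen in place of methyl on a saturated chain carbon, two bonds along the chain from a fluorine atom. Within the data shown here, it is the same kind of change as the one from compound 1 to compound 2, though not the same: there the carbon that loses its methyl is bound to an oxygen on a saturated carbon and a saturated chain carbon, here it stands two bonds along the chain from a fluorine atom. If the step repeats, the value of compound 4 is expected to fall by a number 0.35 log units lower from compound 3 to compound 4 (beyond the scatter) in this assay, an expectation resting on compound 1 and compound 2 and their step of a number 0.35 log units lower from compound 1 to compound 2 (beyond the scatter). Compound 4 is therefore estimated at 0.4, between 0.15 and 0.65.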

Compound 4, partition coefficient: 0.17
For compound 4 the middle estimate is 0.23 log units above the measured one; low and high end bracket the measured number.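

In this assay the replacement of methyl by hydrogen goes the same way on both cores: the new pair gives a number 0.58 log units lower from compound 3 to compound 4 (beyond the scatter), and the earlier pair gives a number 0.35 log units lower from compound 1 to compound 2 (beyond the scatter). The direction of the change therefore carried over from the core of compound 1 to the core of compound 3, even though the carbon that loses its methyl is bound to an oxygen in the earlier pair and stands two bonds along the chain from a fluorine atom in the new one, but two pairs do not establish a fixed size for the step or show that its direction would hold on any other core. Nothing available here accounts for the size of either step.

On these data alone, all four compounds are short fluorinated alcohols, so it remains open whether hydrogen in place of methyl would move the number the same way on a chain ending in an amine or a carboxylic acid instead of the hydroxyl group. As far as these compounds go, a longer chain is equally open, as is a chain carrying a trifluoromethyl group.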